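Ester chain lengthening in the cytotoxicity series

The source may report more compounds than this note shows. Statements on the series, on what has been measured and on what is new or still open speak of the compounds shown alone.

The series varies the alkyl ester on the shared core of compound 1 `CCCOC(=O)CCC(=O)N1CCN(CCCOc2cc3c(Nc4ccc(F)c(Cl)c4)ncnc3cc2OC)CC1`. In a functional assay on A549 cells (Homo sapiens) for cytotoxicity, read by MTT assay, with a stated time of 24 h, tested at 10 uM (a higher number here means a weaker effect of the compound at the concentration tested, a lower number a stronger effect), compound 1 gives 95.1%. Compound 2 `CCCCCCOC(=O)CCC(=O)N1CCN(CCCOc2cc3c(Nc4ccc(F)c(Cl)c4)ncnc3cc2OC)CC1` gives 89.3% in this assay, and compound 3 `CCCCCCCCOC(=O)CCC(=O)N1CCN(CCCOc2cc3c(Nc4ccc(F)c(Cl)c4)ncnc3cc2OC)CC1` gives 87.3%. All three numbers sit close together: a number 5.8 percentage points lower from compound 1 to compound 2 (within the scatter), a number 7.8 percentage points lower from compound 1 to compound 3 (within the scatter) and a number 2 percentage points lower from compound 2 to compound 3 (within the scatter). Compound 3 stands at the lower end of the three numbers, within the scatter of compound 2 and of compound 1 alike.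

Compound 4 `CCCCCCCCCCCCCCOC(=O)CCC(=O)N1CCN(CCCOc2cc3c(Nc4ccc(F)c(Cl)c4)ncnc3cc2OC)CC1` continues the same change: hexyl in place of hydrogen on a saturated chain carbon, eight bonds along the chain from an oxygen next to a carbonyl group. Going by the values given here, the steps that bear on it are the three ester-chain extensions already measured, each within the scatter, so a further extension is not expected to move this assay beyond the scatter either. Compound 4 is therefore expected to give about 84% in this assay, with a range of 72% to 96%. The expected step is a number 3.3 percentage points lower from compound 3 to compound 4 (within the scatter), within the scatter.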

Compound 4, a percentage reported as activity, at one concentration (the size of the read-out at that concentration, not a potency): 100%
Estimate against measurement, compound 4: 16 percentage points below, outside the stated range (above it).
By their numbers in this assay, from the lowest: compounds 3, 2, 1 and 4 (each within the scatter of the next, the first and the last beyond it).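

Going by these compounds alone, the hexyl change at this position, eight bonds along the chain from an oxygen next to a carbonyl group, gives the first steps that lie beyond the scatter in this assay (a number 12.7 percentage points higher from compound 3 to compound 4 (beyond the scatter); a number 10.7 percentage points higher from compound 2 to compound 4 (beyond the scatter)), both modest and both opposite in direction to the steps printed among the shorter chains. Compound 4 does not separate from compound 1 (a number 4.9 percentage points higher from compound 1 to compound 4 (within the scatter)), so the number does not follow ester chain length in a single direction across the series, and compound 4 is the compound that goes against any such trend. Nothing at hand accounts for this turn in direction.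

Still open, as far as these compounds go, is whether a longer chain keeps the number where compound 4 puts it or moves it further. Also open, from the compounds shown here alone, is how an amine or a carboxylic acid in place of the hexyl would read in this assay at this position.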